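The source may hold more compounds than are shown below. What is called first, only, known or untested is meant among the compounds shown, and "the series" means these compounds.

Measured so far:
compound 1 `CC(C)=CCC1Cc2c(OCCCNC(=O)c3ccc([N+](=O)[O-])cc3)cc(=O)n(CCCO)c2CC1(C)C` — in a functional assay on PANC-1 cells (Homo sapiens) for inhibition, read by MTT assay, with a stated time of 24 h, tested at 10 uM (a lower number here means less inhibition, a higher number more inhibition at the concentration tested (going by the name of the read-out)), compound 1 gives 9.1%
compound 2 `CC(C)=CCC1Cc2c(OCCCOc3ccc(Cl)cc3)cc(=O)n(CCCO)c2CC1(C)C` — in this assay compound 2 gives 0%

Compound 2 sits with compound 1 at the low end of the scale, the step of a number 9.1 percentage points lower from compound 1 to compound 2 (within the scatter) lying within the scatter. Compound 3 `CC(C)=CCC1Cc2c(OC(=O)Nc3ccc(Cl)cc3)cc(=O)n(CCCO)c2CC1(C)C` differs from compound 2 by (4-chlorophenyl)carbamoyl in place of 3-(4-chlorophenoxy)propyl on an oxygen on an aromatic ring. Among the measured compounds shown here, the single measured step touched the saturated chain, not the oxygen on the aromatic ring, so nothing measured bears directly on this change. Compound 3 is expected to move by a number 6 percentage points higher from compound 2 to compound 3 (within the scatter), no more than the scatter. The estimate for compound 3 is 6%, ranging from 0% to 22%.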

Compound 3, a percentage reported as inhibition, at one concentration (the size of the read-out at that concentration, not a potency): 0%
For compound 3 the middle estimate is 6 percentage points above the measured one; measured number inside the range.
By their numbers in this assay, from the lowest: compounds 2, 3 and 1 (each within the scatter of the next).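

Among the compounds shown here, until now only the saturated chain had been varied, and this is the first change on the oxygen on an aromatic ring itself. In this assay the exchange of 3-(4-chlorophenoxy)propyl for (4-chlorophenyl)carbamoyl at that oxygen, which brings in a hydrogen-bond donor, gives no change at the digits printed from compound 2 to compound 3 (within the scatter) and leaves both compounds at the low end of the scale. No evidence at hand accounts for this result.

From the compounds shown here alone, whether an amine or a carboxylic acid on the end of a chain at this oxygen would read any differently stays open. So does whether a longer chain there would lift the number.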